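This account rests on a few compounds, and the source may have more. Where it says the series, first, only, none or still open, it means among the compounds named here.

Measured compounds, cytotoxicity data:

compound 1, `O=C(Nc1ccc(F)cc1)c1cc(Cl)ccc1O`, gives 17000 nM in an ADME assay on cells (Macrophage, Mus musculus) for cytotoxicity, read by resazurin assay, with a stated time of 3 days; a lower number here means a stronger inhibitor, a higher number a weaker inhibitor
compound 2, `Cc1c(NC(=O)c2cc(Cl)ccc2O)cccc1C(F)(F)F`, gives 8000 nM in this assay
compound 3, `O=C(Nc1ccc(F)c(C(F)(F)F)c1)c1cc(Cl)ccc1O`, gives 5300 nM in this assay

Compounds 1 and 3 share a core and differ in one place, (trifluoromethyl in place of hydrogen on an aromatic carbon). That change made the step of a 3.2-fold lower number from compound 1 to compound 3 (0.51 log units; beyond the scatter). The difference between the core of compound 2 and the core of compound 1 is not broken down here. The values of compound 2 and compound 3 lie within the scatter of each other, so nothing is said about their order; compound 2 does stand beyond the scatter from compound 1.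

The not yet measured compound 4, `Cc1c(NC(=O)c2cc(Cl)ccc2O)cc(C(F)(F)F)cc1C(F)(F)F`, differs from compound 2 in one place, (trifluoromethyl in place of hydrogen on an aromatic carbon). This is the same kind of change as that from compound 1 to compound 3, but the surroundings are not the same: in compound 3 the entering group sits ortho to a fluoro group and meta to a large group, whereas in compound 4 it sits meta to a large group, meta to a trifluoromethyl group and para to a methyl group. Among the measured compounds shown here, with only one measured instance of this change, the expectation for compound 4 rests on the step of a 3.2-fold lower number from compound 1 to compound 3 (0.51 log units; beyond the scatter) applied to compound 2 at 8000 nM, with a wider range to allow for the different surroundings.

For compound 4 the expected step in this assay is a 2.7-fold lower number from compound 2 to compound 4 (0.43 log units; beyond the scatter). Compound 4 is therefore estimated at 3000 nM, with a range from 1200 nM to 8000 nM.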

Compound 4, half-maximal inhibitory concentration: 3200 nM
Compound 4: middle estimate off by 1.1-fold (0.03 log units), on the low side; the measured number falls inside the stated range.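

In this assay, among the compounds shown here, trifluoromethyl in place of hydrogen on an aromatic carbon gives a 2.5-fold lower number from compound 2 to compound 4 (0.40 log units; beyond the scatter), so the change keeps its direction on a second core and the size of the step does not differ between the two cores: the same change on two cores in this assay, a 3.2-fold lower number (0.51 log units; beyond the scatter) from compound 1 to compound 3 and a 2.5-fold lower number (0.40 log units; beyond the scatter) from compound 2 to compound 4, 1.3-fold (0.11 log units) apart, within the scatter of two such steps This is agreement between only two pairs, and it supports carrying the step to a closely related core as a working estimate, not as a rule for the whole series. The two pairs also differ in the surroundings of the entering group, and with one pair for each set of surroundings, the effect of those surroundings on the step cannot be separated out, nor does this result say anything about how the change behaves in any other assay.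

Left open is whether an amine, a carboxylic acid or a nitrile in place of the same hydrogen would give a step of similar direction and size, since only trifluoromethyl is shown entering here. The chloro and hydroxyl groups are the same in all the compounds shown, so the response of this series to replacing either of them, for example with a methoxy group, also remains open.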